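This account rests on a few compounds, and the source may have more. Where it says the series, first, only, none or still open, it means among the compounds named here.

Compound 1 `Oc1ccc(O)c(-c2cc(-c3ccccc3)nn2-c2ccccc2)c1` carries the shared core with an unsubstituted phenyl at each end. In a functional assay on cells (Cancer cell lines, Homo sapiens) for cytotoxicity, read by sulforhodamine B assay, with a stated time of 48 h (on this read-out higher numbers stand for weaker inhibition of growth and lower numbers for stronger inhibition of growth), compound 1 gives 18600 nM, the highest of the two numbers recorded so far. Compound 2 `Oc1ccc(O)c(-c2cc(-c3ccc(Cl)cc3)nn2-c2ccccc2)c1` differs by chloro in place of hydrogen on an aromatic carbon; in this assay compound 2 gives 17900 nM, and the step of a 1.0-fold lower number from compound 1 to compound 2 (0.02 log units; within the scatter) lies within the scatter. Compound 3 `CC(=O)NS(=O)(=O)c1ccc(-n2nc(-c3ccccc3)cc2-c2cc(O)ccc2O)cc1` is not yet measured; it differs from compound 1 by acetylsulfamoyl in place of hydrogen on an aromatic carbon, the new group sitting on an aromatic carbon of a six-membered aromatic ring of carbon only. Among the measured compounds shown here, the single measured step, from compound 1 to compound 2, touches a different ring and stays within the scatter, so no direct precedent for this change exists and a wide range is kept. Pending the number, compound 3 is expected near 15000 nM (range 5000 nM to 45000 nM), the expected step of a 1.2-fold lower number from compound 1 to compound 3 (0.09 log units; within the scatter) being small and in no settled direction.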

Compound 3, concentration for 50% growth inhibition: 90400 nM
Beside the measured number, compound 3's estimate is 6.0-fold (0.78 log units) below it; measured number above the stated range.
By their numbers in this assay, from the lowest: compounds 2 and 1 (each within the scatter of the next); then compound 3.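

Acetylsulfamoyl in place of hydrogen, on an aromatic carbon of a six-membered aromatic ring of carbon only and para to a large group, gives the first step in the series beyond the scatter in this assay (a 4.9-fold higher number from compound 1 to compound 3 (0.69 log units; beyond the scatter)), and the higher number means weaker inhibition of growth. The only earlier step (a 1.0-fold lower number from compound 1 to compound 2 (0.02 log units; within the scatter)) touched a different ring and stayed within the scatter, so this ring position is the first shown to respond to a change. No measurement on hand accounts for the step.

On these data alone, whether the shift belongs to the whole acetylsulfamoyl group or only to part of it stays open, as does the effect of a plain sulfonamide, an amine or a carboxylic acid at this place. Also open, as far as these compounds go, is how acetylsulfamoyl would behave on the ring that carries the chloro in compound 2.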